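The source may report more compounds than this note shows. Statements on the series, on what has been measured and on what is new or still open speak of the compounds shown alone.

Working notes on the series. Compound 1 `CC(C)(C)[C@@H](N)C(=O)N1CCN(CCCOc2ccc(C(=O)C3CC3)cc2)CC1` and compound 2 `NCCC(=O)N1CCN(CCCOc2ccc(C(=O)C3CC3)cc2)CC1` share one core and differ only at the carbonyl carbon. In an assay for binding affinity to histamine H2 receptor (Homo sapiens) (on this read-out higher numbers stand for weaker inhibition and lower numbers for stronger inhibition), compound 1 gives 19100 nM, and compound 2 gives 100000 nM. For the measured compounds named here, compound 2 therefore stands at the highest of the two numbers so far; the only other compound, compound 1, lies a 5.2-fold higher number from compound 1 to compound 2 (0.72 log units; beyond the scatter) away.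

Compound 3 `C[C@@H](NC(=O)OC(C)(C)C)C(=O)N1CCN(CCCOc2ccc(C(=O)C3CC3)cc2)CC1` is the next unmeasured member. Relative to compound 2 the change is 1-((tert-butoxycarbonyl)amino)ethyl in place of 2-aminoethyl on a carbonyl carbon. Going by the values given here, the one measured step that bears on this site is a 5.2-fold higher number from compound 1 to compound 2 (0.72 log units; beyond the scatter), where a 1-amino-2,2-dimethylpropyl group at the same carbonyl carbon gave the lower number and the 2-aminoethyl group the higher one. Compound 3 again replaces the 2-aminoethyl group with a branched, heavier substituent, so on that single precedent a step back toward lower numbers in this assay is expected, of a modest size and with wide uncertainty given only two measured points. The expected step is a 4.0-fold lower number from compound 2 to compound 3 (0.60 log units; beyond the scatter). For compound 3 the estimate in this assay is 25000 nM, within a range from 6000 nM to 100000 nM.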

Compound 3, inhibition constant: 83200 nM
Compound 3: middle estimate off by 3.3-fold (0.52 log units), on the low side, and the stated range covers the measured number.
By their numbers in this assay, from the lowest: compound 1; then compounds 3 and 2 (each within the scatter of the next).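

In this assay the change to 1-((tert-butoxycarbonyl)amino)ethyl on the carbonyl carbon gives a 1.2-fold lower number from compound 2 to compound 3 (0.08 log units; within the scatter) and so leaves no readable difference, which shows that a larger group with 10 heavy atoms at this position does not by itself reproduce the lower number of compound 1. The comparison with the remaining group gives a 4.4-fold higher number from compound 1 to compound 3 (0.64 log units; beyond the scatter) and, with the earlier step, leaves compound 1 as the only one of the three set apart, with the lowest number and both of its steps beyond the scatter; at this position, then, the 1-amino-2,2-dimethylpropyl group separates from the other two substituents, while size alone does not order the series. No supporting data are available to account for these differences.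

The compounds shown leave open how much of the gap to compound 1 follows the free amine, since 1-aminoethyl, the group of compound 3 without its tert-butoxycarbonyl unit, is not among them. They also leave open whether a tert-butyl group without the neighbouring amine, as in 2,2-dimethylpropyl, would keep the lower number of compound 1.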